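The source may hold more compounds than are shown below. What is called first, only, known or untested is meant among the compounds shown, and "the series" means these compounds.

Compound 1 `Cn1nc2c(=O)n(CC3(O)CCN(Cc4ccc(-c5n[nH]c(=O)o5)cc4Cl)CC3)cnc2c1-c1ccc(CN)cc1` gives 171 nM in an assay on isolated protein for inhibition of ubiquitin carboxyl-terminal hydrolase 7 (Homo sapiens), with stated times of 30 min and 2 h; a lower number here means a stronger inhibitor, a higher number a weaker inhibitor; compound 2 `Cn1nc2c(=O)n(CC3(O)CCN(Cc4ccc(-c5ccncc5)cc4Cl)CC3)cnc2c1-c1ccc(CN)cc1` gives 257 nM in this assay.

Compound 2 and compound 1 lie within the scatter of each other, the step of a 1.5-fold higher number from compound 1 to compound 2 (0.18 log units; within the scatter) being the only one measured. Compound 3 `Cn1nc2c(=O)n(CC3(O)CCN(Cc4ccc(-c5cnco5)cc4Cl)CC3)cnc2c1-c1ccc(CN)cc1` differs from compound 2 by 1,3-oxazol-5-yl in place of pyridin-4-yl on an aromatic carbon. Among the compounds with values here, the one step that bears on this, also an exchange of the ring at that carbon, stayed within the scatter, so no step beyond the scatter is expected in this assay. Compound 3 is therefore estimated at 210 nM, between 100 nM and 450 nM, an expected step of a 1.2-fold lower number from compound 2 to compound 3 (0.09 log units; within the scatter).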

Compound 3, half-maximal inhibitory concentration: 71.6 nM
Compound 3: the middle estimate sits 2.9-fold (0.47 log units) above what was measured, outside the stated range (below it).
By their numbers in this assay, from the lowest: compound 3; then compounds 1 and 2 (each within the scatter of the next).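

In this assay, exchanging the ring on this aromatic carbon can move the number beyond the scatter: 1,3-oxazol-5-yl in place of pyridin-4-yl gives a 3.6-fold lower number from compound 2 to compound 3 (0.56 log units; beyond the scatter), and the same group against the ring of compound 1 gives a 2.4-fold lower number from compound 1 to compound 3 (0.38 log units; beyond the scatter). Ring size alone does not settle the outcome, since compound 1 also carries a five-membered aromatic ring yet lies within the scatter of compound 2. No measurement at hand explains these steps.

Still open, going by these compounds, is whether 1,3-oxazol-2-yl or 1,3-thiazol-5-yl at this carbon would match the 1,3-oxazol-5-yl group, and how a carboxylic acid or an amine there would compare.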